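Working notes: removing the aryl group from the isoxazole bearer

This account rests on a few compounds, and the source may have more. Where it says the series, first, only, none or still open, it means among the compounds named here.

Going by the values given here, compound 2 `CCc1ccc(-c2cc(-c3cn([C@H]4C[C@H](OC(C)=O)[C@@H](COC(C)=O)O4)c(=O)[nH]c3=O)on2)cc1` gives 72.6% in a functional assay on NUGC-3 cells (Homo sapiens) for cytotoxicity, read by sulforhodamine B assay, tested at 10 uM (on this read-out higher numbers stand for more inhibition at the one concentration tested (going by the name of the read-out) and lower numbers for less inhibition), and stands as the lower of the two numbers so far; compound 1 `CC(=O)OC[C@H]1O[C@@H](n2cc(-c3cc(-c4ccccc4)no3)c(=O)[nH]c2=O)C[C@@H]1OC(C)=O` gives 87.6%, the single step between them being a number 15 percentage points lower from compound 1 to compound 2 (beyond the scatter). Compound 3 `CC(=O)OC[C@H]1O[C@@H](n2cc(-c3cc(C)no3)c(=O)[nH]c2=O)C[C@@H]1OC(C)=O` carries methyl in place of 4-ethylphenyl on an aromatic carbon. Among the compounds with values here, this removes the six-membered aromatic ring that the step from compound 1 to compound 2 merely altered, so no measured step covers it directly; the one known step is modest and downward. The estimate for compound 3 in this assay is therefore uncertain, set at 60% with range 30% to 85%, an expected step of a number 12.6 percentage points lower from compound 2 to compound 3 (beyond the scatter).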

Compound 3, a percentage reported as inhibition, at one concentration (the size of the read-out at that concentration, not a potency): 90.8%
Compound 3: middle estimate off by 30.8 percentage points, on the low side; the measured number lies above the stated range.
By their numbers in this assay, from the lowest: compound 2; then compounds 1 and 3 (each within the scatter of the next).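

At this aromatic carbon next to the ring nitrogen, an aromatic ring is not required for a high number in this assay: methyl in place of 4-ethylphenyl gives a number 18.2 percentage points higher from compound 2 to compound 3 (beyond the scatter), while methyl in place of phenyl gives a number 3.2 percentage points higher from compound 1 to compound 3 (within the scatter). Among these compounds, only the 4-ethylphenyl of compound 2 stands apart. Nothing available explains this difference. Open, going by these compounds, is whether an amine, a carboxylic acid or a longer chain at this carbon would keep the number, and whether compound 1 and compound 3 would separate at lower concentrations.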